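Chloro to Cyano on Two Urea Scaffolds

This account rests on a few compounds, and the source may have more. Where it says the series, first, only, none or still open, it means among the compounds named here.

Compound 1 `COc1ccc(CN(C(=O)Nc2ccc(Cl)cc2)n2cnnc2)cc1OC` and compound 2 `COc1ccc(CN(C(=O)Nc2ccc(C#N)cc2)n2cnnc2)cc1OC` share one core, while compound 3 `Cc1ccsc1CN(C(=O)Nc1cccc(Cl)c1)n1cnnc1` and compound 4 `Cc1ccsc1CN(C(=O)Nc1cccc(C#N)c1)n1cnnc1` share another; the difference between the two cores is not broken down here. In a functional assay on MCF7 cells (Homo sapiens) for cytotoxicity, read by MTT assay, with a stated time of 48 h (a lower number here means a stronger inhibitor, a higher number a weaker inhibitor), compound 1 gives > 50000 nM, which is a limit of the assay rather than a number. In this assay compound 2 likewise gives > 50000 nM, again a limit. The change between them is cyano in place of chloro on an aromatic carbon and its step, a step that the two limits leave unreadable from compound 1 to compound 2, cannot be read from two limits. In this assay, for the measured compounds named here, compound 3 gives 31200 nM, the only number among the three. The change from compound 3 to compound 4 is cyano in place of chloro on an aromatic carbon; it is the same kind of change as the earlier one, but the group now sits meta to a large group rather than para to a large group. Since the earlier step left no readable size, the expectation rests mainly on compound 3 at 31200 nM and on (the limit of > 50000 nM in this assay, at which 2 of the 3 values shown sit). Compound 4 is therefore expected to move only by a 1.3-fold higher number from compound 3 to compound 4 (0.11 log units; within the scatter), and its estimated value is 40000 nM, between 15000 nM and 100000 nM.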

Compound 4, half-maximal inhibitory concentration: > 50000 nM
Compound 4 gave a limit, no number (the forecaster's own chance of this, stated with the estimate: 50%); at least 1.2-fold (0.09 log units) between middle value and limit.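

In this assay, cyano in place of chloro on the core of the thiophene-free...

Correcting that opening: in this assay, cyano in place of chloro gives an at least 1.6-fold higher number from compound 3 to compound 4 (0.20 log units; that floor lies within the scatter), so on this core the change can be read only as a floor, and that floor does not by itself establish a real loss. The same change on the other core cannot be read, since compound 1 and compound 2 both stand at a limit, so the two steps cannot be compared in size and nothing shows that the effect carries over quantitatively from one core to the other. The most that can be said is that the cyano compound ends at a limit on both cores, which fits the change travelling without any gain but leaves its size unknown: the limit of > 50000 nM in this assay, at which 3 of the 4 values shown sit.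

Compound 3 gives 31200 nM. Still open, going by these compounds, is whether any other group at this place, such as an amine or a carboxylic acid, would give a number lower than that of compound 3. Also open, on these data alone, is how the two cores compare with the aromatic substituent held the same.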